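This account rests on a few compounds, and the source may have more. Where it says the series, first, only, none or still open, it means among the compounds named here.

Three compounds have been measured in a functional assay on EA.hy 926 cells (Homo sapiens) for cytotoxicity, read by MTT assay, with stated times of 24 h and 12 h, tested at 12.5 uM; a higher number here means a stronger effect of the compound at the concentration tested, a lower number a weaker effect:

Compound 1, `Cc1nc(C)c(C(=O)Oc2ccccc2/C=C/C(=O)O)nc1C`, gives 45.7%.
Compound 2, `COc1ccc(OC(=O)c2nc(C)c(C)nc2C)c(/C=C/C(=O)O)c1`, gives 21.7%.
Compound 3, `CCOC(=O)/C=C/c1cc(OC)c(O)c(OC)c1`, gives 4.9%.

Among these three numbers compound 2 stands second highest. Its nearest neighbour is compound 3, whose number is lower by more than the usual scatter, and its furthest is compound 1, whose number is higher, again beyond the scatter. Among the compounds with values here, the only step measured between compounds that differ in one place is a number 24 percentage points lower from compound 1 to compound 2 (beyond the scatter), which comes from a methoxy in place of hydrogen on an aromatic carbon.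

The next compound, compound 4, is `CCOC(=O)/C=C/c1cc(OC)ccc1OC(=O)c1nc(C)c(C)nc1C`. It differs from compound 2 by ethyl in place of hydrogen on an oxygen next to a carbonyl group. Within the data shown here, no measured step covers this change on its own: compound 3 carries an ethyl on the corresponding oxygen, but it also differs from compound 2 in several other places, so its value shows only that such an ester can sit low in this assay, not how much of that comes from the ethyl. With only this indirect hint, the expected step is a number 9.7 percentage points lower from compound 2 to compound 4 (within the scatter), downward, with a wide range. For compound 4 the estimate in this assay is 12%, between 2% and 35%.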

Compound 4, a percentage reported as activity, at one concentration (the size of the read-out at that concentration, not a potency): 15.9%
Beside the measured number, compound 4's estimate is 3.9 percentage points below it; the range from low to high includes it.
By their numbers in this assay, from the lowest: compound 3; then compounds 4 and 2 (each within the scatter of the next); then compound 1.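

In this assay, within the data shown here, ethyl in place of hydrogen on an oxygen next to a carbonyl group gives a number 5.8 percentage points lower from compound 2 to compound 4 (within the scatter) and is the first direct reading of this change, since compound 3 differs from compound 2 in several places at once. At this one concentration, carboxy and ethoxycarbonyl therefore cannot be told apart in this pair, so the hydrogen of the free acid in compound 2 is not required for a read-out of this size. Among these compounds, this contrasts with the only other single-place change measured, a number 24 percentage points lower from compound 1 to compound 2 (beyond the scatter), which lies on the other side of the scatter, although two steps at different places show nothing general about the series, and nothing available explains either of them.

The compounds shown leave open whether a methyl, a longer chain such as butyl, or a chain carrying an amine on this same oxygen would also stay within the scatter of compound 2. They also leave open whether ethyl on this oxygen would give a similarly small step on compound 1, which has hydrogen where compound 2 carries its methoxy.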